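This account rests on a few compounds, and the source may have more. Where it says the series, first, only, none or still open, it means among the compounds named here.

Three amides of the same kind were tested in a functional assay on KB 3-1 cells (Homo sapiens) for cytotoxicity, read by MTT assay, with a stated time of 68 h; a lower number here means a stronger inhibitor, a higher number a weaker inhibitor. Compound 1 `O=C(Nc1cccc(-c2ccccc2C(F)(F)F)c1)C(Cl)Cl` gives 35900 nM in this assay. For compound 2 `O=C(Nc1cccc(-c2ccsc2)c1)C(Cl)Cl` only a limit of the assay, > 50000 nM, is known. Compound 3 `O=C(Nc1cccc(-c2cccc(NC(=O)C(Cl)Cl)c2)c1)C(Cl)Cl` carries two such amide groups and likewise reaches only a limit of the assay, > 50000 nM. Compound 3 thus stands at the weak end of what has been measured, sharing (the limit of > 50000 nM in this assay, at which 2 of the 3 values shown sit). Compound 4 `Nc1cccc(-c2cccc(NC(=O)C(Cl)Cl)c2)c1` differs from it in one place: hydrogen in place of (dichloromethyl)carbonyl on a nitrogen on an aromatic ring. For the measured compounds named here, since no measured step of this kind exists and compound 3 itself gave only a limit, the change is expected to bring no shift beyond the scatter, an estimated step of an at least 1.1-fold lower number from compound 3 to compound 4 (0.04 log units; that floor lies within the scatter). Compound 4 is therefore estimated at 45000 nM, with a likely range from 15000 nM to 100000 nM, and a limit rather than a number remains quite possible.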

Compound 4, half-maximal inhibitory concentration: 26100 nM
The estimate for compound 4 lay 1.7-fold (0.24 log units) above the measured number; measured number inside the range.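

Replacing (dichloromethyl)carbonyl with hydrogen on this nitrogen leaves a free amino group and gives, in this assay, an at least 1.9-fold lower number from compound 3 to compound 4 (0.28 log units; that floor lies within the scatter). So the second amide group is not needed for a measured number here, although the true size of the step stays unknown. Compound 3 gave only a limit: the limit of > 50000 nM in this assay, at which 2 of the 4 values shown sit.

Going by these compounds, it remains open whether an acetyl group on this nitrogen would behave like the amino group or like the (dichloromethyl)carbonyl group. On these data alone, the effect of a methyl group there is equally open.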